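Removing one methoxy from compound 3: cytotoxicity notes

The source may report more compounds than this note shows. Statements on the series, on what has been measured and on what is new or still open speak of the compounds shown alone.

Compound 1 `CCOC(=O)c1cc(/C=C/c2ccccc2)on1`: "not determined" (no result reported)
Compound 2 `CCOC(=O)c1cc(/C=C/c2ccc(C(F)(F)F)cc2)on1`: "not determined" (no result reported)
Compound 3 `CCOC(=O)c1cc(/C=C/c2cc(OC)cc(OC)c2)on1`: > 128000 nM

All three entries refer to an ADME assay on Vero cells (Chlorocebus sabaeus) for cytotoxicity, with a stated time of 72 h; on this read-out higher numbers stand for weaker inhibition and lower numbers for stronger inhibition. Compound 1 and compound 2 carry no result, so neither can serve as a reference point. In this assay compound 3 stands at > 128000 nM, which is a limit of the assay and not a number. For the measured compounds named here, the series therefore holds no exact value and no measured step between compounds.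

The next compound is compound 4 `CCOC(=O)c1cc(/C=C/c2cccc(OC)c2)on1`, which differs from compound 3 at a single place: hydrogen in place of methoxy on an aromatic carbon. This puts hydrogen in place of methoxy on an aromatic carbon, meta to a large group and meta to a methoxy group.

Going by the values given here, with no measured step to draw on, no change beyond the usual scatter is expected in this assay, and no direction can be argued. The only anchor for this expectation is compound 3, whose > 128000 nM is a limit. The expected move is a number no higher from compound 3 to compound 4 (the limit leaves the size open), an estimate that takes the limit as its starting point. A report of a limit rather than a number is the likelier outcome. For compound 4 the estimated value is 128000 nM, with an expected range of 60000 nM to 256000 nM.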

Compound 4, half-maximal inhibitory concentration: > 128000 nM
Compound 4: no number, only a limit; the forecaster's own chance of this, stated with the estimate: 75%; the middle value lies on the limit itself.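

In this assay, compound 3 and compound 4 each end at a limit of the assay and not at a number, so no step can be read between them: the limit of > 128000 nM in this assay, at which 2 of the 4 values shown sit.

The compounds shown leave open whether hydrogen in place of methoxy on an aromatic carbon shifts the result in this assay at all.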